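Removing the Bromo Group from Compound 2

The compounds below may be only part of what the source reports. "The series", "measured", "known", "first", "only" and "open" are said of these compounds alone.

In a functional assay, with a stated time of 30 min (a lower number here means a stronger inhibitor, a higher number a weaker inhibitor), compound 1 `CCCCOc1cc(OC)c(Br)cc1C(C)=O` gives 42300000 nM, compound 2 `CCCCCCOc1cc(OC)c(Br)cc1C(C)=O` gives 42400000 nM, and compound 3 `CCCCCCCCCCCCCCOc1cc(OC)c(Br)cc1C(C)=O` gives 16100000 nM. Compound 2 thus stands level with compound 1 at the high end of these numbers, with compound 3 lower. Compound 4 `CCCCCCOc1cc(OC)ccc1C(C)=O` differs from compound 2 by hydrogen in place of bromo on an aromatic carbon. The two measured steps, a 1.0-fold higher number from compound 1 to compound 2 (0.00 log units; within the scatter) and a 2.6-fold lower number from compound 2 to compound 3 (0.42 log units; beyond the scatter), both lengthen the chain, and neither touches the bromo group. They therefore give only a loose guide, and no step beyond the scatter is expected in this assay. The expected step is a 1.1-fold lower number from compound 2 to compound 4 (0.03 log units; within the scatter), and its direction remains uncertain. Compound 4 is estimated at 40000000 nM, with an expected range of 15000000 nM to 100000000 nM.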

Compound 4, half-maximal inhibitory concentration: 42600000 nM
For compound 4 the middle estimate is 1.1-fold (0.03 log units) below the measured one, and the stated range covers the measured number.
By their numbers in this assay, from the lowest: compound 3; then compounds 1, 2 and 4 (each within the scatter of the next).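

Replacing bromo with hydrogen at the aromatic carbon ortho to a methoxy group and meta to an acetyl group gives a 1.0-fold higher number from compound 2 to compound 4 (0.00 log units; within the scatter) in this assay, so the number does not respond to this change. The earlier steps shown here altered only the chain and said nothing about this position. No measurement shown here accounts for this result. On these data alone, it remains open whether an amine or a carboxylic acid at this position would shift the number, and whether removing bromo would matter with the longer chain of compound 3.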